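Replacing the Methylpiperazine with a Triazole on a Sulfonyl Compound

The source may hold more compounds than are shown below. What is called first, only, known or untested is meant among the compounds shown, and "the series" means these compounds.

Measured so far:
compound 1, `CN1CCN(c2ccc(C3=NN(C(=O)/C=C/c4ccccc4)C(c4ccc(N(C)C)cc4)C3)cc2)CC1` — 35.9%
compound 2, `CN1CCN(c2ccc(C3=NN(S(C)(=O)=O)C(c4ccc(N(C)C)cc4)C3)cc2)CC1` — 0.6%
compound 3, `CN1CCN(c2ccc(C3=NN(S(=O)(=O)c4ccc(C#N)cc4)C(c4ccc(N(C)C)cc4)C3)cc2)CC1` — 99.8%

Of the compounds shown here, three sharing one core have been tested in a functional assay on MDA-MB-231 cells (Homo sapiens) for inhibition, read by sulforhodamine B assay, tested at 10 uM; on this read-out higher numbers stand for more inhibition at the one concentration tested (going by the name of the read-out) and lower numbers for less inhibition. Compound 3 stands highest of the three; compound 1 is nearest to it, and compound 2 is furthest. The step from compound 1 to compound 2 is a number 35.3 percentage points lower from compound 1 to compound 2 (beyond the scatter), the step from compound 1 to compound 3 is a number 63.9 percentage points higher from compound 1 to compound 3 (beyond the scatter), and the step from compound 2 to compound 3 is a number 99.2 percentage points higher from compound 2 to compound 3 (beyond the scatter), so the read-out across these three spans almost its whole range.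

Compound 4, `CN(C)c1ccc(C2CC(c3ccc(-n4cncn4)cc3)=NN2S(=O)(=O)c2ccc(C#N)cc2)cc1`, differs from compound 3 in one place: 1H-1,2,4-triazol-1-yl in place of 4-methylpiperazin-1-yl on an aromatic carbon. None of the three measured steps touches this position; all of them vary the group on the ring nitrogen, which compound 4 keeps unchanged from compound 3. Within the data shown here, no measured step therefore bears directly on this change, and the expectation rests on compound 3 alone, whose value 99.8% sits close to the top of the scale. Compound 4 is expected to keep a high number in this assay, with a small downward step a number 14.8 percentage points lower from compound 3 to compound 4 (beyond the scatter) allowed for the untested change. The estimate for compound 4 is 85%, ranging from 50% to 100%.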

Compound 4, a percentage reported as inhibition, at one concentration (the size of the read-out at that concentration, not a potency): 32.8%
Estimate against measurement, compound 4: 52.2 percentage points above; measured number outside the range, below it.
By their numbers in this assay, from the lowest: compound 2; then compounds 4 and 1 (each within the scatter of the next); then compound 3.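

In this assay, the exchange of 4-methylpiperazin-1-yl for 1H-1,2,4-triazol-1-yl gives a number 67 percentage points lower from compound 3 to compound 4 (beyond the scatter), so this aromatic carbon, para to a large group, is a position where the choice of group matters. The earlier steps shown here varied only the group on the ring nitrogen; with (4-cyanophenyl)sulfonyl held fixed, this step shows that the high number of compound 3 is not carried by that group alone. The change replaces a six-membered non-aromatic ring with a five-membered aromatic ring with 3 hetero atoms, and no accompanying measurement indicates which difference between the two groups accounts for the drop.

The compounds shown leave open whether a morpholin-4-yl group, an unsubstituted piperazin-1-yl group or an open-chain amine such as dimethylamino at this position would stay near compound 3 or fall as compound 4 does. They also leave open whether 1H-1,2,4-triazol-1-yl would give a step of similar size alongside methylsulfonyl or (2-phenylethenyl)carbonyl on the ring nitrogen.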